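Swapping the aminophenyl of compound 1 for a dichlorophenyl

The source may hold more compounds than are shown below. What is called first, only, known or untested is meant among the compounds shown, and "the series" means these compounds.

Measured so far:
- compound 1 `COc1cc(-c2cc(/C=C/C(=O)c3ccc(N)cc3)[nH]n2)cc(OC)c1OC`: -19%
- compound 2 `COc1ccc(-c2cc(/C=C/C(=O)c3ccc(OC)c(OC)c3)[nH]n2)cc1`: -89%

Of the compounds shown here, two sharing the same core have been tested in a functional assay on 786-0 cells (Homo sapiens) for cytotoxicity, read by sulforhodamine B assay, with a stated time of 48 h, tested at 10 uM; a higher number here means a weaker effect of the compound at the concentration tested, a lower number a stronger effect. In this assay compound 1 gives -19%, the highest of the two numbers, while compound 2 gives -89%, a number lying well beyond the scatter below it. Within the data shown here, the two compounds differ in more than one place, so no single step between them can be read.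

Compound 3 `COc1cc(-c2cc(/C=C/C(=O)c3ccc(Cl)c(Cl)c3)[nH]n2)cc(OC)c1OC` is not yet measured. It differs from compound 1 in one place: 3,4-dichlorophenyl in place of 4-aminophenyl on a carbonyl carbon. Whether a chlorinated ring on the carbonyl carbon behaves more like the aminophenyl of compound 1 or drifts toward the far lower number of compound 2 cannot be told from the two values in hand. Among the measured compounds shown here, the only comparison available shows that changes to this part of the molecule can move the read-out by a large amount. A step in this assay of moderate size, toward a lower number, is therefore expected for a number 26 percentage points lower from compound 1 to compound 3 (beyond the scatter), with wide uncertainty. Compound 3 is estimated to give about -45%, somewhere between -90% and 5%.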

Compound 3, a percentage reported as activity, at one concentration (the size of the read-out at that concentration, not a potency): 50%
Compound 3: middle estimate off by 95 percentage points, on the low side; measured number outside the range, above it.
By their numbers in this assay, from the lowest: compound 2; then compound 1; then compound 3.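

In this assay, the group on the carbonyl carbon now proves able to change the read-out on its own: with the rest of compound 1 kept, 3,4-dichlorophenyl in place of 4-aminophenyl gives a number 69 percentage points higher from compound 1 to compound 3 (beyond the scatter). The earlier pair could not show this, as compound 1 and compound 2 differ in more than one place, so the large gap between them could not be assigned to any one part of the molecule. This single exchange also marks the dichlorophenyl as the weaker of the two groups in this setting at the concentration tested, though nothing measured here explains that difference.

The exchange removes an amine and adds two chlorines in one step, so the compounds shown cannot tell whether losing the amine, gaining the chlorines or both account for the change. As far as these compounds go, an unsubstituted phenyl, a phenyl with a single chlorine or a phenyl carrying a carboxylic acid at this carbonyl carbon, with the rest of compound 1 unchanged, would help separate those contributions, and whether the same exchange has a similar effect on other cores remains open.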